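Ester to Ether at the Side-Chain Oxygen of Compound 1

This account rests on a few compounds, and the source may have more. Where it says the series, first, only, none or still open, it means among the compounds named here.

Measured in a functional assay on HeLa cells (Homo sapiens) for cytotoxicity, read by MTT assay; a higher number here means a weaker inhibitor, a lower number a stronger inhibitor:
Compound 1 `CC(C)=CC[C@@H](OC(=O)C1CCCO1)C1=CC(=O)c2c(O)ccc(O)c2C1=O` gives 17000 nM.
Compound 2 `CCCCC(CC(=O)O[C@H](CC=C(C)C)C1=CC(=O)c2c(O)ccc(O)c2C1=O)OC(C)=O` gives 73500 nM.
Compound 3 `CC(C)=CC[C@@H](OC(=O)CC(O)c1ccccc1)C1=CC(=O)c2c(O)ccc(O)c2C1=O` gives 44500 nM.

Compound 1 stands lowest of the three, with compound 3 nearest and compound 2 furthest. Compound 4 `CCC(CO[C@H](CC=C(C)C)C1=CC(=O)c2c(O)ccc(O)c2C1=O)OC` differs from it by 2-methoxybutyl in place of (oxolan-2-yl)carbonyl on an oxygen on a saturated carbon. Within the data shown here, no measured step replaces the whole (oxolan-2-yl)carbonyl group; the nearest are a 4.3-fold higher number from compound 1 to compound 2 (0.64 log units; beyond the scatter) and a 2.6-fold higher number from compound 1 to compound 3 (0.42 log units; beyond the scatter), which only exchange the oxolan-2-yl for another group on the carbonyl carbon and both raise the number modestly. By that loose analogy a modest rise in this assay is expected, with wide uncertainty. For compound 4 the estimate is 35000 nM, between 12000 nM and 100000 nM, a step of a 2.1-fold higher number from compound 1 to compound 4 (0.31 log units; beyond the scatter).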

Compound 4, half-maximal inhibitory concentration: 63500 nM
Compound 4: the middle estimate sits 1.8-fold (0.26 log units) below what was measured, within the range that was stated.
By their numbers in this assay, from the lowest: compound 1; then compounds 3, 4 and 2 (each within the scatter of the next).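

With the carbonyl gone as well as the ring, the ether compound 4 shows a change larger than a swap on the carbonyl carbon alone: in this assay there is a 3.7-fold higher number from compound 1 to compound 4 (0.57 log units; beyond the scatter). Across the four compounds, every replacement at this position leaves a number higher than that of compound 1, whether or not the carbonyl stays. No measurement offered here explains this rise. On these data alone, the carbonyl and the ring leave together, so their separate contributions stay open. As far as these compounds go, whether an (oxolan-2-yl)methyl group on this oxygen, keeping the ring without the carbonyl, would restore the number of compound 1 also remains open.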